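The source may hold more compounds than are shown below. What is called first, only, known or untested is meant among the compounds shown, and "the series" means these compounds.

Working notes on the series. In a physicochemical assay for pharmacokinetics, at pH 6 (on this read-out lower numbers stand for a shorter-lived compound and higher numbers for a longer-lived compound), compound 1 `O=C(Sc1cccnc1C(=O)O)c1ccc(Cl)cc1` gives 7.9 h and compound 2 `COc1cccc(C(=O)Sc2cccnc2C(=O)O)c1` gives 11.9 h. Compound 1 holds the lowest of just two numbers, but the two values lie within the scatter of each other, so the series shows no real separation so far. Within the data shown here, these two compounds do not differ in one place, and no measured step is available as a guide.

The next compound is compound 3 `O=C(Sc1cccnc1C(=O)O)c1ccc([N+](=O)[O-])cc1`, with nitro in place of chloro on an aromatic carbon, para to a large group: nitro in place of chloro on an aromatic carbon. With only the structural change to go on, a modest downward move in this assay is expected, not clearly beyond the scatter. The estimated step is a 1.8-fold lower number from compound 1 to compound 3 (0.24 log units; within the scatter). For compound 3 the expected half-life is 4.5 h, with an estimated range of 1.5 h to 10 h.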

Compound 3, half-life: 1.4 h
For compound 3 the middle estimate is 3.2-fold (0.51 log units) above the measured one; measured number below the stated range.
By their numbers in this assay, from the lowest: compound 3; then compounds 1 and 2 (each within the scatter of the next).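

Nitro in place of chloro gives the first step in the series that can be read at a single place, and in this assay it amounts to a 5.6-fold lower number from compound 1 to compound 3 (0.75 log units; beyond the scatter) on an aromatic carbon para to a large group. This shows that the half-life is sensitive to the group at this position, a point the earlier pair, which differs in more than one place, could not settle. Nothing at hand bears on what lies behind this step.

As far as these compounds go, it remains open whether another group at this place, such as an amine or a nitrile, would leave the half-life close to that of compound 1 or shorten it as well. From the compounds shown here alone, a single step gives no trend across groups, and whether the same change would have a similar effect elsewhere on the aromatic ring also remains open.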